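Replacing the isopropyl group of compound 2

The compounds below may be only part of what the source reports. "The series", "measured", "known", "first", "only" and "open" are said of these compounds alone.

Measured in a functional assay on MV4-11 cells (Homo sapiens) for antiproliferative activity, read by CCK-8 assay, with a stated time of 72 h; on this read-out higher numbers stand for weaker inhibition and lower numbers for stronger inhibition:
- compound 1 `Cc1cc(F)cc(C)c1Oc1ccc(C(C)(C)O)cc1-c1cn(C)c(=O)c2[nH]c(C(=O)NCc3ccc(C(=O)NO)cc3)cc12`: 440 nM
- compound 2 `CC(C)Oc1ccc(C(C)(C)O)cc1-c1cn(C)c(=O)c2[nH]c(C(=O)NCCCCCCC(=O)NO)cc12`: 160 nM
- compound 3 `Cn1cc(-c2ccccc2Oc2ccccc2)c2cc(C(=O)NCCCC(=O)NO)[nH]c2c1=O`: 380 nM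

Compound 2 has the lowest number of the three, 160 nM, which means the strongest inhibition here. Its gaps to compound 3 and compound 1 are both beyond the usual scatter.

Compound 4 `Cc1cc(F)cc(C)c1Oc1ccc(C(C)(C)O)cc1-c1cn(C)c(=O)c2[nH]c(C(=O)NCCCCCCC(=O)NO)cc12` is built from compound 2 by putting 4-fluoro-2,6-dimethylphenyl in place of isopropyl on an oxygen on an aromatic ring. Within the data shown here, no measured pair of compounds shows this change alone. The nearest evidence is compound 1, which carries the same 4-fluoro-2,6-dimethylphenoxy group and gives 440 nM, but it also differs from compound 2 elsewhere, so it offers only a loose guide. The step expected in this assay is a 1.2-fold lower number from compound 2 to compound 4 (0.09 log units; within the scatter), which would stay within the scatter. For compound 4 the estimated value is 130 nM, with an expected range from 45 nM to 400 nM.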

Compound 4, half-maximal inhibitory concentration: 300 nM
The estimate for compound 4 lay 2.3-fold (0.36 log units) below the measured number; measured number inside the range.
By their numbers in this assay, from the lowest: compounds 2, 4, 3 and 1 (each within the scatter of the next, the first and the last beyond it).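

In this assay putting 4-fluoro-2,6-dimethylphenyl in place of isopropyl on the oxygen gives a 1.9-fold higher number from compound 2 to compound 4 (0.27 log units; within the scatter) and so, in this one pair, an added aromatic ring and a rise from 3 to 9 heavy atoms leave a difference too small to read as real. With the 4-fluoro-2,6-dimethylphenoxy group held constant, 5-(hydroxycarbamoyl)pentyl in place of 4-(hydroxycarbamoyl)phenyl gives a 1.5-fold lower number from compound 1 to compound 4 (0.17 log units; within the scatter) and so these two groups cannot be told apart in this assay either. Nothing among the available data explains these results. From the compounds shown here alone, whether a methyl group or a 2-aminoethyl group on this oxygen would move the number beyond the scatter remains open. So does the effect of a longer chain carrying the hydroxycarbamoyl group.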